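The compounds below may be only part of what the source reports. "The series", "measured", "known", "first", "only" and "open" are said of these compounds alone.

- Compound 1 `CC(=O)OCc1cc(N)c(Nc2ccc(C#N)cc2)cc1Oc1c(C)cc(C#N)cc1C` gives 113000 nM in the assay below
- Compound 2 `COCc1cc(N)c(Nc2ccc(C#N)cc2)cc1Oc1c(C)cc(/C=C/C#N)cc1C` gives 50300 nM in the same assay
- Compound 3 `CC(=O)OCc1cc(N)c(Nc2ccc(C#N)cc2)cc1Oc1c(C)cc(/C=C/C#N)cc1C` is not yet measured

In an ADME assay on MT2 cells (Homo sapiens) for cytotoxicity (on this read-out lower numbers stand for higher toxicity in this test and higher numbers for lower toxicity in this test), compound 2 (50300 nM) holds the lower of the two numbers, and the gap up to compound 1 lies beyond the scatter. Compound 3 carries acetyl in place of methyl on an oxygen on a saturated carbon. Within the data shown here, no measured pair isolates this change. Among the measured compounds shown here, compound 1 (113000 nM) also carries acetoxymethyl and is the only guide. A small upward shift is expected, probably within the scatter (a 1.3-fold higher number from compound 2 to compound 3 (0.11 log units; within the scatter)). The estimate for compound 3 is 65000 nM as the middle value, with an expected range from 25000 nM to 160000 nM overall.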

Compound 3, half-maximal cytotoxic concentration in the MT2 assay: 96300 nM
The estimate for compound 3 lay 1.5-fold (0.17 log units) below the measured number; measured number inside the range.
By their numbers in the MT2 assay, from the lowest: compounds 2, 3 and 1 (each within the scatter of the next, the first and the last beyond it).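

In the MT2 assay, acetyl in place of methyl on the oxygen gives a 1.9-fold higher number from compound 2 to compound 3 (0.28 log units; within the scatter), and 2-cyanoethenyl in place of cyano on an aromatic carbon gives a 1.2-fold lower number from compound 1 to compound 3 (0.07 log units; within the scatter), so neither single change separates the compounds on this read-out. In a physicochemical assay for solubility, read by HPLC, at pH 7.4 (on this read-out lower numbers stand for lower solubility and higher numbers for higher solubility), compound 2 gives 0.11 ug/mL and compound 3 gives 0.49 ug/mL. The acetyl for methyl change does separate them in the physicochemical assay: the measured solubility of compound 2, 0.11 ug/mL, and of compound 3, 0.49 ug/mL, a 4.5-fold higher number (0.65 log units; beyond the scatter)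

On these data alone, whether butyryl, a longer acyl chain or a carbamoyl group on that same oxygen would keep the higher number in the physicochemical assay while leaving the MT2 assay undisturbed stays open.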